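The source may report more compounds than this note shows. Statements on the series, on what has been measured and on what is new or still open speak of the compounds shown alone.

Measured compounds in a functional assay on the whole organism for inhibition, with Rattus norvegicus as the target, read by cytopathic effect and paw edema, at a dose of 100 mg/kg by the oral route; on this read-out higher numbers stand for more inhibition at the one dose given (going by the name of the read-out) and lower numbers for less inhibition:
Compound 1, `O=C(NN1CCOCC1)c1c(O)c2cccnc2n(-c2ccccc2)c1=O`, gives -26.2%.
Compound 2, `Cc1ccc(NC(=O)c2c(O)c3cccnc3n(-c3ccccc3)c2=O)cc1`, gives 2.2%.
Compound 3, `COc1ccc(NC(=O)c2c(O)c3cccnc3n(-c3ccccc3)c2=O)cc1`, gives -1.9%.

Compound 2 stands highest of the three numbers, but its lead over compound 3 is within the usual scatter, so the two cannot be ranked against each other; only compound 1 lies clearly lower. The three compounds share one core and differ only in the group on the amide-type nitrogen.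

Compound 4, `O=C(NCc1ccncc1)c1c(O)c2cccnc2n(-c2ccccc2)c1=O`, carries a change on that same nitrogen: (pyridin-4-yl)methyl in place of 4-methylphenyl on an amide-type nitrogen.

Going by the values given here, two measured steps bear on this place. Going a number 28.4 percentage points higher from compound 1 to compound 2 (beyond the scatter) and a number 24.3 percentage points higher from compound 1 to compound 3 (beyond the scatter) shows that exchanging the group on the amide-type nitrogen can move the read-out by a modest amount. The step of a number 4.1 percentage points lower from compound 2 to compound 3 (within the scatter) shows that a small swap on an aromatic carbon did not. Among the compounds with values here, no measured pair contains a (pyridin-4-yl)methyl group, so the direction is uncertain; because compound 1 gives -26.2% while compound 2 gives 2.2%, a downward move of modest size is expected.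

Compound 4 is estimated at -8%, within -32% to 16%, an expected step of a number 10.2 percentage points lower from compound 2 to compound 4 (beyond the scatter).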

Compound 4, a percentage reported as inhibition, in the whole organism at one dose (the size of the read-out at that dose, not a potency): 15.4%
Beside the measured number, compound 4's estimate is 23.4 percentage points below it; low and high end bracket the measured number.
By their numbers in this assay, from the lowest: compound 1; then compounds 3 and 2 (each within the scatter of the next); then compound 4.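

The change to (pyridin-4-yl)methyl on the amide-type nitrogen reads as a number 13.2 percentage points higher from compound 2 to compound 4 (beyond the scatter) and as a number 17.3 percentage points higher from compound 3 to compound 4 (beyond the scatter), so in this assay this position can lift the number clearly above both aromatic amides, and compound 4 stands highest of the four. Against morpholin-4-yl the same group gives a number 41.6 percentage points higher from compound 1 to compound 4 (beyond the scatter), the widest step here, so this one place spans more of the read-out than the earlier compounds revealed. Nothing available explains why this group gives the higher number.

From the compounds shown here alone, the change brings in a ring nitrogen and a carbon link at once, so it stays open which of the two matters, and a phenylmethyl group or a pyridin-4-yl group on the same nitrogen would separate them. Also open, going by these compounds, is whether a longer chain, such as 2-(pyridin-4-yl)ethyl, would go further.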